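Amine nitrogen substitution from compound 1 to compound 4

The source may report more compounds than this note shows. Statements on the series, on what has been measured and on what is new or still open speak of the compounds shown alone.

Compound 1 `Cc1cc(N[C@H](CCCCN)C(=O)NO)cc(C)c1F` is the starting point for this step. In a physicochemical assay for lipophilicity, at pH 7.4 (on this read-out higher numbers stand for higher lipophilicity and lower numbers for lower lipophilicity), compound 1 gives < 3, which is a limit and not a number. Compound 2 `Cc1cc(S(=O)(=O)NCCCC[C@@H](Nc2cc(C)c(F)c(C)c2)C(=O)NO)ccc1F` gives < 3, also a limit. Compound 3 `Cc1cc(NC(=O)NCCCC[C@@H](Nc2cc(C)c(F)c(C)c2)C(=O)NO)ccc1F` gives < 3, again a limit. For the measured compounds named here, the series so far therefore stands at the limit of < 3 in this assay, at which 3 of the 3 values shown sit, with no numerical value available.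

Compound 4 `Cc1cc(N[C@H](CCCCNCc2ccccc2F)C(=O)NO)cc(C)c1F` carries 2-fluorobenzyl in place of hydrogen on an amine nitrogen. Going by the values given here, no step between measured compounds is available to size this change, so any expectation in this assay is rough. The direction expected is upward, and the estimated step is a step that the limit leaves unreadable from compound 1 to compound 4, though its size is poorly fixed without a number for compound 1. The expectation that compound 4 stays within the limit leans on compound 3, at < 3. For compound 4 the estimated value is 2, with an expected range of 1 to 3.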

Compound 4, distribution coefficient: < 3
Compound 4: no number, only a limit; the forecaster's own chance of this, stated with the estimate: 85%; the middle value lies beyond the limit too.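

No step from compound 1 to compound 4 can be read in this assay, because both compounds give only limits and the series stays at one shared limit: the limit of < 3 in this assay, at which 4 of the 4 values shown sit.

The compounds shown leave open whether 2-fluorobenzyl in place of hydrogen on an amine nitrogen changes this read-out at all.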